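Isopropyl for cyclopentyl on two related cores

The compounds below may be only part of what the source reports. "The series", "measured", "known", "first", "only" and "open" are said of these compounds alone.

Compound 1, `Cc1c(OCCCCOc2ccc(C(=O)O)cc2F)ccc(C(=O)CC2CCCC2)c1O`: 83.8%
Compound 2, `Cc1c(OCCCCOc2ccc(C(=O)O)cc2)ccc(C(=O)CC2CCCC2)c1C`: 16.2%
Compound 3, `Cc1c(OCCCCOc2ccc(C(=O)O)cc2F)ccc(C(=O)CC(C)C)c1O`: 85%

The three measured compounds were tested in an assay on HEK293 cells for positive allosteric modulation of metabotropic glutamate receptor 2 (Rattus norvegicus), read by thallium flux, with a stated time of 2.5 min; on this read-out lower numbers stand for smaller maximal responses and higher numbers for larger maximal responses. In this assay compound 1 reaches 83.8% and compound 3 reaches 85%. Compound 3 differs from compound 1 by isopropyl in place of cyclopentyl on a saturated chain carbon bound to a carbonyl carbon, and that change gave a number 1.2 percentage points higher from compound 1 to compound 3 (within the scatter). Compound 2, which gives 16.2% in this assay, stands lowest of the three, and its gaps to compound 1 and to compound 3 both lie beyond the scatter. The difference between the core of compound 2 and the core of compound 1 is not broken down here.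

Compound 4 `Cc1c(OCCCCOc2ccc(C(=O)O)cc2)ccc(C(=O)CC(C)C)c1C` has not yet been measured in this assay. It differs from compound 2 by isopropyl in place of cyclopentyl on a saturated chain carbon bound to a carbonyl carbon. Among the compounds with values here, this is the same change as the one from compound 1 to compound 3, now made on the core of compound 2.

Because the step of a number 1.2 percentage points higher from compound 1 to compound 3 (within the scatter) stayed within the scatter, the same change on compound 2 is expected to produce a step of similar size, estimated as a number 1.8 percentage points higher from compound 2 to compound 4 (within the scatter). The expectation rests only on that single earlier step and on the value of compound 2, which is 16.2%. Compound 4 is therefore estimated to reach 18% in this assay. The expected range for compound 4 runs from 6% to 36%.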

Compound 4, largest response reached (reported as percent of maximum), in percent of the reference or control that the assay uses: 19%
Beside the measured number, compound 4's estimate is 1 percentage points below it, and the stated range covers the measured number.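

On the core of compound 2, replacing cyclopentyl with isopropyl on a saturated chain carbon bound to a carbonyl carbon gave in this assay a number 2.8 percentage points higher from compound 2 to compound 4 (within the scatter), so the response stayed low, with compound 4 at 19% in the same range as its parent. Set beside the earlier step, the new one shows that the change carried over between these two cores without a detectable difference in its outcome: the same change on two cores in this assay, a number 1.2 percentage points higher (within the scatter) from compound 1 to compound 3 and a number 2.8 percentage points higher (within the scatter) from compound 2 to compound 4, 1.6 percentage points apart, within the scatter of two such steps. This holds for these two pairs only: it shows that isopropyl and cyclopentyl could be exchanged at this place on both cores without a step beyond the scatter, but with so small a step on each core it does not show a real effect being transferred, and it does not predict the outcome on any other core.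

The compounds shown leave open which difference between the core of compound 1 and the core of compound 2 goes with the gap in response, since those cores differ by both the fluorine and the hydroxyl that compound 2 lacks. They also leave open whether the exchange would remain this quiet with a larger group at this place, such as cyclohexyl, or with a group carrying an amine.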